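The source may report more compounds than this note shows. Statements on the series, on what has been measured and on what is new or still open speak of the compounds shown alone.

Among the compounds with values here, only two compounds have so far been measured in a functional assay on A2780 cells (Homo sapiens) for antiproliferative activity, read by MTT assay, with a stated time of 48 h; on this read-out lower numbers stand for stronger inhibition and higher numbers for weaker inhibition. There, compound 1 `COc1ccc2c(/C=C/C(=O)c3cc(OC)c(OC)c([N+](=O)[O-])c3)c[nH]c2c1` gives 742 nM and compound 2 `COc1cc(C(=O)/C=C/c2cn(C)c3ccccc23)cc([N+](=O)[O-])c1OC` gives 1890 nM. Compound 2 therefore holds the higher of the two numbers, making it the weaker inhibitor of the pair, and the gap between them lies beyond the usual scatter of repeated measurements. These two compounds differ in more than one place, however, so their gap cannot be credited to any single group.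

Compound 3 `COc1ccc2c(/C=C/C(=O)c3cc(OC)c(OC)c([N+](=O)[O-])c3)cn(C)c2c1` comes from compound 2 through one change: methoxy in place of hydrogen on an aromatic carbon. Within the data shown here, no measured pair isolates this change. Among the measured compounds shown here, the only guide is compound 1, which also carries this methoxy and reads 742 nM in this assay. That value suggests a modest move towards lower numbers, a little beyond the scatter, though the evidence is thin. The expected change is a 2.7-fold lower number from compound 2 to compound 3 (0.43 log units; beyond the scatter). For compound 3 the estimated value is 700 nM, with an expected range of 170 nM to 2500 nM.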

Compound 3, half-maximal inhibitory concentration: 952 nM
Beside the measured number, compound 3's estimate is 1.4-fold (0.13 log units) below it; low and high end bracket the measured number.
By their numbers in this assay, from the lowest: compounds 1, 3 and 2 (each within the scatter of the next, the first and the last beyond it).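

In this assay, putting methoxy in place of hydrogen on this aromatic carbon of the fused system gives a step that stays within the usual scatter of repeated measurements (a 2.0-fold lower number from compound 2 to compound 3 (0.30 log units; within the scatter)), so at this position the change cannot be told apart from repeat noise. Compound 3 also supplies the single-change link that the earlier pair lacked, and methyl in place of hydrogen on the aromatic nitrogen likewise stays within the scatter (a 1.3-fold higher number from compound 1 to compound 3 (0.11 log units; within the scatter)), so neither change taken alone has a measurable effect on this read-out. Nothing measured here explains why these numbers fall as they do.

The compounds shown leave open whether a different group on the same aromatic carbon, such as a chlorine atom or a dimethylamino group, would move the number beyond the scatter. They also leave open what a longer chain on the aromatic nitrogen, such as a propyl or butyl group, would do in place of methyl.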